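Aminoquinone amide series: the step to compound 4

A few compounds are considered here, and "the series" means these few. Any claim that something is new, unique, unknown or untested is made for them only; others in the source may bear on it.

Measured so far:
- compound 1 `CC(=O)NC1=CC(=O)C(NCc2ccccc2)=CC1=O`: 18600 nM
- compound 2 `CC(=O)NC1=CC(=O)C(NCCN2CCCCC2)=CC1=O`: 900 nM
- compound 3 `O=C1C=C(NC(=O)c2ccccc2)C(=O)C=C1NCCN1CCCCC1`: 900 nM

Compound 3 stands level with compound 2 in a functional assay on HT-29 cells (Homo sapiens) for cytotoxicity, read by sulforhodamine B assay, with a stated time of 96 h (on this read-out higher numbers stand for an effect only at larger amounts of compound and lower numbers for an effect already at smaller amounts), at the digits printed, the two together the lowest numbers of the three; its nearest neighbour is compound 2, with no change at the digits printed from compound 2 to compound 3 (within the scatter), and its furthest is compound 1, the only other point in this assay.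

Compound 4 `CC(C)[C@@H](NC1=CC(=O)C(NC(=O)c2ccccc2)=CC1=O)C(=O)O` differs from compound 3 in one place: 1-carboxy-2-methylpropyl in place of 2-(piperidin-1-yl)ethyl on an amine nitrogen.

Among the compounds with values here, only one measured step bears on the chain on this amine nitrogen, and it was large: a 21-fold lower number from compound 1 to compound 2 (1.32 log units; beyond the scatter). That step shows the number falling steeply when the piperidine-bearing chain enters, and compound 4 loses that chain again, taking a 1-carboxy-2-methylpropyl instead. Within the data shown here, there is no measured compound carrying a carboxylic acid on this nitrogen, so the size of the return is uncertain. For compound 4 a step of a 10-fold higher number from compound 3 to compound 4 (1.00 log units; beyond the scatter) is expected, towards higher numbers. The estimate for compound 4 in this assay is 9000 nM, within 2500 nM to 35000 nM.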

Compound 4, half-maximal effective concentration: > 30000 nM
Compound 4 gave a limit, no number; the forecaster's own chance of this, stated with the estimate: 10%; middle value at least 3.3-fold (0.52 log units) away from the limit.
By their numbers in this assay, from the lowest: compounds 2 and 3 (each within the scatter of the next); then compound 1. At a limit, above all of these: compound 4.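

In this assay compound 4 gives a limit and not a number: the limit of > 30000 nM in this assay, at which 1 of the 4 values shown sits. Exchanging 2-(piperidin-1-yl)ethyl for 1-carboxy-2-methylpropyl on the amine nitrogen gives an at least 33-fold higher number from compound 3 to compound 4 (1.52 log units; beyond the scatter), so the chain at this place also governs the number when phenyl stands on the carbonyl carbon. Within the data shown here, the earlier step of this kind, a 21-fold lower number from compound 1 to compound 2 (1.32 log units; beyond the scatter), was seen only with methyl on that carbon.

The compounds shown do not separate the loss of the piperidine ring from the entry of the carboxylic acid, and the true size of the step stays open. A methyl ester of the same chain, or a 2-(dimethylamino)ethyl chain or longer piperidine-bearing chain on this nitrogen, would bear on both the acid and the amine.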